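From Ester to Hydroxymethyl: An Expected Gain in Potency

The source may report more compounds than this note shows. Statements on the series, on what has been measured and on what is new or still open speak of the compounds shown alone.

Measured compounds:
compound 1 `O=C(CCl)N1CCCC(n2nc(-c3ccc(Oc4ccccc4)cc3)cc2CO)C1` – 400 nM
compound 2 `C=CC(=O)N1CCCC(n2nc(-c3ccc(Oc4ccccc4)cc3)cc2C(=O)OCC)C1` – 44000 nM

For the measured compounds named here, in a functional assay on Z-138 cells (Homo sapiens) for inhibition, read by luminescence and CellTiter-Glo, with a stated time of 72 h (a higher number here means a weaker inhibitor, a lower number a stronger inhibitor), compound 2 gives 44000 nM, the highest of the two numbers measured so far. The nearest is compound 1, which gives 400 nM, a gap far beyond the scatter of repeated runs.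

Compound 3 `C=CC(=O)N1CCCC(n2nc(-c3ccc(Oc4ccccc4)cc3)cc2CO)C1` has not been measured. It differs from compound 2 by hydroxymethyl in place of ethoxycarbonyl on an aromatic carbon. Compound 3 shares the hydroxymethyl group with compound 1, whose value 400 nM sits much lower, so a large drop in number is expected for a 22-fold lower number from compound 2 to compound 3 (1.34 log units; beyond the scatter). For compound 3 a value around 2000 nM is estimated, expected to fall between 400 nM and 10000 nM.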

Compound 3, half-maximal inhibitory concentration: 14600 nM
The estimate for compound 3 lay 7.3-fold (0.86 log units) below the measured number, and the stated range ends below it.
By their numbers in this assay, from the lowest: compound 1; then compound 3; then compound 2.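

In this assay, hydroxymethyl in place of ethoxycarbonyl on this aromatic carbon brings only a modest gain, with a 3.0-fold lower number from compound 2 to compound 3 (0.48 log units; beyond the scatter). The large change comes at the carbonyl carbon instead: vinyl in place of chloromethyl gives a 37-fold higher number from compound 1 to compound 3 (1.56 log units; beyond the scatter), so the low value of compound 1 does not carry over to compound 3 through the shared hydroxymethyl group. Nothing available explains either step.

Going by these compounds, whether a carboxylic acid or an amine on this aromatic carbon would do better than hydroxymethyl remains open. So does the effect of chloromethyl on the carbonyl carbon when ethoxycarbonyl sits on the aromatic carbon.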